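Phenyl in Place of Ethynyl: Expected Growth Inhibition

The compounds below may be only part of what the source reports. "The series", "measured", "known", "first", "only" and "open" are said of these compounds alone.

Compound 1 `NC(=O)c1ncn2c(=O)n(Cc3ccco3)nnc12` gives > 50000 nM in a functional assay on U-373MG ATCC cells for inhibition, with U373 MG (Homo sapiens) as the target, read by MTT assay, with a stated time of 7 days (a higher number here means a weaker inhibitor of growth, a lower number a stronger inhibitor of growth), which is a limit of the assay rather than a number.
Compound 2 `C#CC/N=N/Nc1[nH]cnc1C(N)=O` gives 32000 nM in this assay.

Among the measured compounds shown here, compound 2 therefore holds the only numerical value shown; the other entry is the limit of > 50000 nM in this assay, at which 1 of the 2 values shown sits. Compound 3 `NC(=O)c1nc[nH]c1N/N=N/Cc1ccccc1` has not yet been measured. It differs from compound 2 by phenyl in place of ethynyl on a saturated chain carbon bound to a double-bonded nitrogen. For the measured compounds named here, no step between two measured compounds is known here, so only a small shift is expected, near the usual scatter, with no firm direction. Compound 3 is expected to give about 25000 nM in this assay, between 8000 nM and 80000 nM. This corresponds to an expected step of a 1.3-fold lower number from compound 2 to compound 3 (0.11 log units; within the scatter).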

Compound 3, concentration for 50% growth inhibition: > 50000 nM
Compound 3: a limit, no number; the forecaster's own chance of this, stated with the estimate: 30%; middle value at least 2.0-fold (0.30 log units) from the limit.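

Phenyl in place of ethynyl on a saturated chain carbon bound to a double-bonded nitrogen gives an at least 1.5-fold higher number from compound 2 to compound 3 (0.19 log units; that floor lies within the scatter) in this assay. Swapping ethynyl for this aromatic ring therefore does not bring growth inhibition into the range where a number can be read. The true size of the step stays unknown, and compound 2 remains the only compound with a number: the limit of > 50000 nM in this assay, at which 2 of the 3 values shown sit.

Going by these compounds, whether a methyl group, a longer chain or a phenyl ring carrying an amine would give a measurable value at this place remains open.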